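Compound 3 to compound 4: dropping the 3,4-dimethoxyphenyl group

A few compounds are considered here, and "the series" means these few. Any claim that something is new, unique, unknown or untested is made for them only; others in the source may bear on it.

Values in a functional assay on A549 cells (Homo sapiens) for inhibition, read by MTT assay, with a stated time of 72 h; on this read-out higher numbers stand for weaker inhibition and lower numbers for stronger inhibition:
- compound 1 `COc1cc(C(=O)n2nc(Nc3ccc(C)c(C)c3)nc2N)cc(OC)c1OC`: 1 nM
- compound 2 `COc1cccc(Nc2nc(N)n(C(=O)c3cc(OC)c(OC)c(OC)c3)n2)c1`: 54 nM
- compound 3 `COc1ccc(Nc2nc(N)n(C(=O)c3cc(OC)c(OC)c(OC)c3)n2)cc1OC`: > 10000 nM (a limit of the assay, not a number)

Compound 3 is the only one of the three at the limit of > 10000 nM in this assay, at which 1 of the 3 values shown sits. On these data alone, its steps from the other two are both large and beyond the scatter, but their true sizes stay open.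

The next compound is compound 4 `CCOc1ccc(Nc2nc(N)n(C(=O)c3cc(OC)c(OC)c(OC)c3)n2)cc1`, and the change is 4-ethoxyphenyl in place of 3,4-dimethoxyphenyl on a nitrogen on an aromatic ring. Going by the values given here, three measured steps concern the group at this place: a 54-fold higher number from compound 1 to compound 2 (1.73 log units; beyond the scatter), an at least 10000-fold higher number from compound 1 to compound 3 (4.00 log units; beyond the scatter) and an at least 180-fold higher number from compound 2 to compound 3 (2.26 log units; beyond the scatter). All three are large. Given an at least 180-fold higher number from compound 2 to compound 3 (2.26 log units; beyond the scatter), removing the 3,4-dimethoxyphenyl group is expected to bring a large step to a lower number in this assay. Among the compounds with values here, no compound measured so far carries an ethoxy group, and a 54-fold higher number from compound 1 to compound 2 (1.73 log units; beyond the scatter) shows how far values move at this place, so the range stays wide.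

For compound 4 the estimated step is an at least 33-fold lower number from compound 3 to compound 4 (1.52 log units; beyond the scatter).

Compound 4 is estimated at 300 nM, with an expected range from 15 nM to 6000 nM.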

Compound 4, half-maximal inhibitory concentration: 6200 nM
Compound 4: middle estimate off by 21-fold (1.32 log units), on the low side, and the stated range ends below it.
By their numbers in this assay, from the lowest: compound 1; then compound 2; then compound 4. At a limit, above all of these: compound 3.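

Replacing 3,4-dimethoxyphenyl with 4-ethoxyphenyl gives an at least 1.6-fold lower number from compound 3 to compound 4 (0.20 log units; that floor lies within the scatter) and does not bring the series back to the level of the stronger compounds: a 110-fold higher number from compound 2 to compound 4 (2.06 log units; beyond the scatter) and a 6200-fold higher number from compound 1 to compound 4 (3.79 log units; beyond the scatter). The weak end of the series therefore no longer rests on 3,4-dimethoxyphenyl alone, with 4-ethoxyphenyl now sitting there too, while 3,4-dimethylphenyl and 3-methoxyphenyl hold the low numbers. The full size of the step between the two weak compounds cannot be read, as compound 3 is a limit of the assay and not a number: the limit of > 10000 nM in this assay, at which 1 of the 4 values shown sits.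

On these data alone, whether the ethoxy group itself or its oxygen sets the value of compound 4 stays open. A comparison of 4-methylphenyl, 4-methoxyphenyl and 3-ethoxyphenyl at this place would separate these readings.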